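Furan-2-yl for thiophen-3-yl at the pyridine carbon

The source may hold more compounds than are shown below. What is called first, only, known or untested is meant among the compounds shown, and "the series" means these compounds.

The series keeps one core and varies the five-membered or six-membered ring at one carbon of the central ring. Compound 3 `Oc1ccc(-c2cc(-c3ccsc3)nc(-c3cccc(Cl)c3)c2)cc1` gives 7390 nM in a functional assay on T47D cells (Homo sapiens) for cytotoxicity, read by CCK-8 assay and cell counting, with a stated time of 2 days; a lower number here means a stronger inhibitor, a higher number a weaker inhibitor; it is the second highest of the three numbers measured. Compound 1 `Oc1ccc(-c2cc(-c3cccc(Cl)c3)nc(-c3cccs3)c2)cc1` gives 5350 nM in this assay, and compound 2 `Oc1ccc(-c2cc(-c3cccnc3)nc(-c3cccc(Cl)c3)c2)cc1` gives 25700 nM. Within the data shown here, the step of a 1.4-fold higher number from compound 1 to compound 3 (0.14 log units; within the scatter) lies within the scatter, whereas a 3.5-fold lower number from compound 2 to compound 3 (0.54 log units; beyond the scatter) and a 4.8-fold higher number from compound 1 to compound 2 (0.68 log units; beyond the scatter) are the only changes beyond it.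

Compound 4 `Oc1ccc(-c2cc(-c3cccc(Cl)c3)nc(-c3ccco3)c2)cc1` differs from compound 3 by furan-2-yl in place of thiophen-3-yl on an aromatic carbon. Among the measured compounds shown here, the closest precedent is the exchange of one five-membered ring for another, a 1.4-fold higher number from compound 1 to compound 3 (0.14 log units; within the scatter), which stayed within the scatter; the larger step of a 3.5-fold lower number from compound 2 to compound 3 (0.54 log units; beyond the scatter) involved a six-membered ring and bears less on this change. For compound 4 the expected step of a 1.1-fold lower number from compound 3 to compound 4 (0.06 log units; within the scatter) is therefore small, with no clear direction beyond the scatter. The estimate for compound 4 in this assay is 6500 nM, with a range from 2500 nM to 17000 nM.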

Compound 4, half-maximal inhibitory concentration: 5220 nM
Beside the measured number, compound 4's estimate is 1.2-fold (0.10 log units) above it; the measured number falls inside the stated range.
By their numbers in this assay, from the lowest: compounds 4, 1 and 3 (each within the scatter of the next); then compound 2.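

In this assay, furan-2-yl gives a third five-membered ring at this carbon that cannot be separated from the two thiophene isomers: a 1.4-fold lower number from compound 3 to compound 4 (0.15 log units; within the scatter) and a 1.0-fold lower number from compound 1 to compound 4 (0.01 log units; within the scatter) both lie within the scatter. Among these compounds, this extends the tolerance seen between the thiophenes to a ring with oxygen in place of sulfur, while a 4.9-fold lower number from compound 2 to compound 4 (0.69 log units; beyond the scatter) lies beyond the scatter and leaves pyridin-3-yl in compound 2 as the only group here set apart from the five-membered rings. The data at hand offer no explanation for that separation.

Going by these compounds, whether unsubstituted phenyl at this carbon would fall with compound 2 or with the five-membered rings remains open. So does the response to a non-aromatic group here, such as an amine or a longer alkyl chain.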